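Replacing 4-Ethylpiperidin-1-yl with Cyclohexylsulfanyl on the Shared Core

This account rests on a few compounds, and the source may have more. Where it says the series, first, only, none or still open, it means among the compounds named here.

Compound 1 `CC(C(=O)NCc1ccc(C(F)(F)F)cc1N1CCCCCC1)c1ccc(NS(C)(=O)=O)c(F)c1` gives 1.6 nM in an assay on CHO cells for antagonist activity at transient receptor potential cation channel subfamily V member 1 (Homo sapiens), read by FLIPR; on this read-out higher numbers stand for weaker inhibition and lower numbers for stronger inhibition.
Compound 2 `CCC1CCN(c2cc(C(F)(F)F)ccc2CNC(=O)C(C)c2ccc(NS(C)(=O)=O)c(F)c2)CC1` gives 0.7 nM in this assay.

Among the compounds with values here, of the two measured numbers, compound 2 has the lower one, and the single known step, a 2.3-fold lower number from compound 1 to compound 2 (0.36 log units; beyond the scatter), separates it from compound 1. That step exchanged one nitrogen-linked ring for another at the same place on the shared core.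

Compound 3 `CC(C(=O)NCc1ccc(C(F)(F)F)cc1SC1CCCCC1)c1ccc(NS(C)(=O)=O)c(F)c1` is the next compound, and it differs from compound 2 by cyclohexylsulfanyl in place of 4-ethylpiperidin-1-yl on an aromatic carbon. Within the data shown here, no measured step bears directly on this change: the one step known kept the nitrogen link and only altered the ring, whereas here the ring is joined through sulfur and the ring nitrogen is gone. Among the measured compounds shown here, the only guide is that the earlier change at this place was modest, so a step of similar or somewhat larger size is plausible, with the direction uncertain.

Compound 3 is therefore expected at 1.5 nM, within a range of 0.4 nM to 6 nM. That estimate corresponds to a 2.1-fold higher number from compound 2 to compound 3 (0.33 log units; beyond the scatter), a mild weakening that might still fall within the scatter.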

Compound 3, inhibition constant: 0.5 nM
Compound 3: the middle estimate sits 3.0-fold (0.48 log units) above what was measured; measured number inside the range.
By their numbers in this assay, from the lowest: compounds 3 and 2 (each within the scatter of the next); then compound 1.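

In this assay, this place on an aromatic carbon, ortho to a large group and meta to a trifluoromethyl group, is shown to accept a ring joined through sulfur as well as one joined through nitrogen. Putting cyclohexylsulfanyl in place of 4-ethylpiperidin-1-yl gives a 1.4-fold lower number from compound 2 to compound 3 (0.15 log units; within the scatter) and so leaves compound 2 and compound 3 indistinguishable, even though the ring nitrogen is gone and the ring is now carbon only. Measured against the azepan-1-yl group, cyclohexylsulfanyl gives a 3.2-fold lower number from compound 1 to compound 3 (0.51 log units; beyond the scatter) as a modest step towards stronger inhibition, and no accompanying data explain how these results arise.

Still open, going by these compounds, is what the sulfur link itself contributes: an oxygen link or a methylene link carrying the same cyclohexyl ring would separate the effect of the link from that of the ring. Also open, on these data alone, is how far this place tolerates other kinds of group, such as an open hexyl chain, or a cyclohexyl ring carrying an amine or a carboxylic acid.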